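The compounds below may be only part of what the source reports. "The series", "measured", "known", "first", "only" and "open" are said of these compounds alone.

Measured so far:
- compound 1, `CC(C)C(O)(C(=O)O)c1ccc(-c2ccc3ccccc3c2)[nH]c1=O`: 544 nM
- compound 2, `CCn1ncc2c(F)cc(-c3ccc(C(CC)(CC)c4nnc[nH]4)c(=O)[nH]3)cc21`: 17 nM
- compound 3, `CC(C)C(c1ccc(-c2ccc3cccc(F)c3c2)[nH]c1=O)N1CCN/C1=N\C#N`: 23 nM

In an assay on CHO cells for displacement of a labelled ligand from prostaglandin E2 receptor EP3 subtype (Homo sapiens), read by radioligand binding (a higher number here means a weaker inhibitor, a lower number a stronger inhibitor), compound 3 gives 23 nM. Among the three numbers this is the second highest; the nearest is compound 2, which lies within the scatter of it, and the furthest is compound 1, which stands a good deal higher, beyond the scatter. Compounds 2 and 3 thus show that a polar five-membered heterocycle carried on the saturated chain carbon next to the shared core is compatible with strong inhibition in this assay, whereas the hydroxy acid of compound 1 is not.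

The unmeasured compound 4, `CC(C)C(/C=C1/CCNC1=O)c1ccc(-c2ccc3cccc(F)c3c2)[nH]c1=O`, is compound 3 with a group of 7 heavy atoms (5 carbon, 1 nitrogen, 1 oxygen; one five-membered non-aromatic ring with 1 hetero atom) in place of a group of 8 heavy atoms (4 carbon, 4 nitrogen; one five-membered non-aromatic ring with 2 hetero atoms), on a saturated chain carbon bound to an aromatic carbon and a saturated chain carbon. The donor count is kept, one acceptor is lost, and the new group is joined through a double bond rather than a ring nitrogen. For the measured compounds named here, no directly comparable step is available among the measured compounds. A small loss is expected, of modest size, though within the scatter cannot be excluded; the expected step of a 2.2-fold higher number from compound 3 to compound 4 (0.34 log units; beyond the scatter) reflects this. For compound 4 the estimate in this assay is 50 nM, with a range from 15 nM to 200 nM.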

Compound 4, inhibition constant: 5.3 nM
Compound 4: the middle estimate sits 9.4-fold (0.97 log units) above what was measured, and the stated range ends above it.
By their numbers in this assay, from the lowest: compound 4; then compounds 2 and 3 (each within the scatter of the next); then compound 1.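

In this assay, putting the group of 7 heavy atoms in place of the group of 8 heavy atoms on this saturated chain carbon gives a 4.3-fold lower number from compound 3 to compound 4 (0.64 log units; beyond the scatter) and so improves inhibition. At this position, strong inhibition therefore needs neither the nitrile nor a ring nitrogen as the point of attachment: the entering five-membered ring has 1 hetero atom instead of 2, is joined through a double bond, and carries 1 hydrogen-bond acceptor instead of 2, with the donor count kept. No measurement at hand accounts for the size or direction of this step.

Whether the double bond itself matters remains open, since no saturated link to the same ring is shown. Also open, on these data alone, is how a simple primary amide or an open-chain amine on this carbon would behave in this assay.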